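Bromophenyl Replacing Methoxyphenyl on the Hydrazone Thiazole Series

The source may report more compounds than this note shows. Statements on the series, on what has been measured and on what is new or still open speak of the compounds shown alone.

Three compounds of this series carry a measurement in a functional assay on HepG2 cells (Homo sapiens) for inhibition, read by MTT assay, with a stated time of 48 h; on this read-out lower numbers stand for stronger inhibition and higher numbers for weaker inhibition. Compound 1 `COc1cc(/C=N/Nc2nc(-c3ccccc3)cs2)c(Br)c(Br)c1OC` gives 33600 nM in this assay. Compound 2 `Fc1ccc(/C=N/Nc2nc(-c3ccc(C(F)(F)F)cc3)cs2)cc1F` gives 14500 nM in this assay. Compound 3 `COc1ccccc1-c1csc(N/N=C/c2ccc(F)c(F)c2)n1` is recorded only as a limit of the assay, > 100000 nM in this assay, so compound 3 stands apart from the two compounds that carry a number; this is the limit noted as the limit of > 100000 nM in this assay, at which 1 of the 3 values shown sits.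

Among the measured compounds shown here, no step between two measured compounds that differ in a single place is available, so the step to compound 4 has to be judged from compound 2 and compound 3 together. Compound 4 `Fc1ccc(/C=N/Nc2nc(-c3ccc(Br)cc3)cs2)cc1F` differs from compound 3 in one place: 4-bromophenyl in place of 2-methoxyphenyl on an aromatic carbon. Compound 4 keeps the difluorophenyl hydrazone side of compound 2 and exchanges the 4-trifluoromethylphenyl of compound 2 for 4-bromophenyl.

Compound 4 is expected to come back into the measurable range, because compound 2 with the same hydrazone side gives 14500 nM in this assay. Compound 4 is accordingly estimated at 20000 nM in this assay, with a range from 6000 nM to 80000 nM. This means an expected step of an at least 5.0-fold lower number from compound 3 to compound 4 (0.69 log units; beyond the scatter) in this assay, though the chance that compound 4 also returns only a limit remains real.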

Compound 4, half-maximal inhibitory concentration: > 100000 nM
Compound 4: no number, only a limit; the forecaster's own chance of this, stated with the estimate: 25%; at least 5.0-fold (0.69 log units) between middle value and limit.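

With the difluorophenyl hydrazone side held fixed, bromo in place of trifluoromethyl gives an at least 6.8-fold higher number from compound 2 to compound 4 (0.83 log units; beyond the scatter) in this assay, so this single exchange on the phenyl group is enough to lose the measurable value. The earlier compounds offered no such direct comparison, and this is the first readable step in the series. 4-Bromophenyl in place of 2-methoxyphenyl does not bring the series back into the measurable range, and the step between these two limits cannot be read, so compound 3 and compound 4 cannot be ranked against each other: the limit of > 100000 nM in this assay, at which 2 of the 4 values shown sit.

As far as these compounds go, with this hydrazone side, a number is so far seen only for compound 2, and how far compound 3 and compound 4 lie beyond the limit remains unknown. Still open, from the compounds shown here alone, is whether trifluoromethyl is the only substituent at this place of the phenyl group that keeps a number, or whether a nitrile, an amine or a carboxylic acid there would also give one.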